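The compounds below may be only part of what the source reports. "The series", "measured", "known", "first", "only" and "open" are said of these compounds alone.

Compound 1 `CC(=O)N1N=C(c2ccc3ccccc3c2)OC1c1ccccc1`: 2.11 ug/mL
Compound 2 `COc1ccc(C2OC(c3ccc4ccccc4c3)=NN2C(C)=O)cc1`: 3.6 ug/mL
Compound 3 `CC(=O)N1N=C(c2ccc3ccccc3c2)OC1c1ccccc1Cl`: 4.32 ug/mL

These numbers come from a functional assay on HepG2 cells (Homo sapiens) for antiproliferative activity, read by MTT assay, with a stated time of 48 h; a lower number here means a stronger inhibitor, a higher number a weaker inhibitor. Compound 3 stands apart from compound 1 by a modest margin, a 2.0-fold higher number from compound 1 to compound 3 (0.31 log units; beyond the scatter). It cannot be told apart from compound 2, given a 1.2-fold higher number from compound 2 to compound 3 (0.08 log units; within the scatter). Compound 4 `CC(=O)N1N=C(c2ccc3ccccc3c2)OC1c1ccccc1[N+](=O)[O-]` has nitro in place of chloro on an aromatic carbon. Within the data shown here, no nitro compound has been measured, so the guidance is indirect. Methoxy in place of hydrogen gave a 1.7-fold higher number from compound 1 to compound 2 (0.23 log units; within the scatter), which is also small. Among the measured compounds shown here, with only small steps so far, no clear shift is expected, and the expected step is a 1.1-fold lower number from compound 3 to compound 4 (0.03 log units; within the scatter). For compound 4 the estimate is 4 ug/mL, with an expected range from 1.8 ug/mL to 9 ug/mL.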

Compound 4, half-maximal inhibitory concentration: 12.3 ug/mL
Estimate against measurement, compound 4: 3.1-fold (0.49 log units) below; the whole stated range lies below it.
By their numbers in this assay, from the lowest: compounds 1, 2 and 3 (each within the scatter of the next, the first and the last beyond it); then compound 4.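

In this assay, the aromatic carbon ortho to a large group proves sensitive to which group it carries: nitro in place of chloro gives a 2.8-fold higher number from compound 3 to compound 4 (0.45 log units; beyond the scatter), a larger step than any among the first three compounds. The other steps, a 3.4-fold higher number from compound 2 to compound 4 (0.53 log units; beyond the scatter) and a 5.8-fold higher number from compound 1 to compound 4 (0.77 log units; beyond the scatter), also lie beyond the scatter, making compound 4 the weakest of the four. Nothing available here explains this loss. Open, as far as these compounds go, is whether nitro would give the same result elsewhere on this ring, and how an amine or a carboxylic acid would fare at this position.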